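The compounds below may be only part of what the source reports. "The series", "measured", "known", "first", "only" and "open" are said of these compounds alone.

Measured in an ADME assay on J774.A1 cells (Mus musculus) for cytotoxicity, read by MTT assay, with a stated time of 72 h; a higher number here means that more compound is tolerated, a lower number that less compound is tolerated:
- compound 1 `COC(=O)C1=C(C)N(c2ccc(OC)cc2)C(C)=C(C(=O)OC)C1[C@@H]1O[C@H]2OC(C)(C)O[C@H]2[C@@H]1OCc1ccccc1`: 14.1 ug/mL
- compound 2 `COC(=O)C1=C(C)N(c2ccc(Cl)cc2)C(C)=C(C(=O)OC)C1[C@@H]1O[C@H]2OC(C)(C)O[C@H]2[C@@H]1OCc1ccccc1`: 4.22 ug/mL
- compound 3 `COC(=O)C1=C(C)N(c2ccc(F)cc2)C(C)=C(C(=O)OC)C1[C@@H]1O[C@H]2OC(C)(C)O[C@H]2[C@@H]1OCc1ccccc1`: "not determined" (no result reported)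

Only two of these compounds have a number, and compound 2, at 4.22 ug/mL, holds the lower one. Compound 1 stands above it by a margin beyond the usual scatter, while compound 3 gave no result and so cannot be ranked. The next compound to be tested is compound 4 `COC(=O)C1=C(C)N(c2ccc(Cl)cc2)C(C)=C(C(=O)OC)C1[C@@H]1O[C@H]2OC(C)(C)O[C@H]2[C@@H]1O`, which keeps the chloro group of compound 2 and changes the other end of the molecule: hydrogen in place of benzyl on an oxygen on a saturated carbon. In words, hydrogen stands in place of benzyl on an oxygen on a saturated carbon, so the benzyloxy group becomes hydroxy.

Within the data shown here, no measured step covers this change. The only one available is a 3.3-fold lower number from compound 1 to compound 2 (0.52 log units; beyond the scatter), which exchanges methoxy for chloro on an aromatic carbon elsewhere in the molecule. It therefore offers a guide to size, not to direction. The change removes a whole benzyl group. A step of similar modest size is expected, though its direction is uncertain. The leaning is toward more compound being tolerated in this assay, and the estimate is a 2.8-fold higher number from compound 2 to compound 4 (0.45 log units; beyond the scatter). For compound 4 the expected value is 12 ug/mL, with an estimated range from 4 ug/mL to 40 ug/mL.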

Compound 4, half-maximal cytotoxic concentration: 35.5 ug/mL
Beside the measured number, compound 4's estimate is 3.0-fold (0.47 log units) below it; low and high end bracket the measured number.
By their numbers in this assay, from the lowest: compound 2; then compound 1; then compound 4.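

In this assay, the oxygen on a saturated carbon proves to be a place where the substituent strongly affects how much compound is tolerated: hydrogen in place of benzyl, turning benzyloxy into hydroxy, brings an 8.4-fold higher number from compound 2 to compound 4 (0.92 log units; beyond the scatter). Among these compounds, this step is larger than a 3.3-fold lower number from compound 1 to compound 2 (0.52 log units; beyond the scatter), so in this pair of changes the group on that oxygen moves the number further than the exchange on the aromatic carbon, something the earlier compounds, all of which carry benzyl there, could not show. Nothing available here accounts for the size or direction of the step.

The hydroxy form is shown only with the chloro group on the aromatic ring, so it remains open whether the same step would appear with methoxy or fluoro there. The compounds shown also do not tell whether a small group on this oxygen, such as methyl or acetyl, would give a number closer to that of the benzyloxy form or the hydroxy form.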